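The source may report more compounds than this note shows. Statements on the series, on what has been measured and on what is new or still open speak of the compounds shown alone.

In an ADME assay on PC-3 cells (Homo sapiens) for cytotoxicity, read by WST assay, tested at 100 uM (on this read-out lower numbers stand for less inhibition and higher numbers for more inhibition at the one concentration tested (going by the name of the read-out)), the measured compounds stand as follows:

compound 1 `O=C(Nc1ccc(Cl)cc1)C1CCCN(C(=O)c2cccc(-c3cnco3)c2)C1` gives 0%
compound 2 `O=C(Nc1cccc(-c2cnco2)c1)C1CCCN(C(=O)c2cc(C(F)(F)F)cc(C(F)(F)F)c2)C1` gives 9%
compound 3 `Cc1nc(-c2cccc(C(=O)N3CCCC(C(=O)Nc4ccc(Cl)cc4)C3)c2)cs1` gives 1%

All three share a core, though the difference between the core of compound 1 and the core of compound 2 is not broken down here. Compound 3 arises from compound 1 by 2-methyl-1,3-thiazol-4-yl in place of 1,3-oxazol-5-yl on an aromatic carbon, and the step of a number 1 percentage points higher from compound 1 to compound 3 (within the scatter) in this assay lies within the scatter. Compound 4 `Cc1nc(-c2cccc(NC(=O)C3CCCN(C(=O)c4cc(C(F)(F)F)cc(C(F)(F)F)c4)C3)c2)cs1` is the not yet measured partner of compound 2 under the same change, (2-methyl-1,3-thiazol-4-yl in place of 1,3-oxazol-5-yl on an aromatic carbon), at the same kind of place on the ring.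

Since the step from compound 1 to compound 3 barely moved the read-out, the expected step for compound 4 is a number 1 percentage points higher from compound 2 to compound 4 (within the scatter), because compound 2 stands at 9% and the earlier change was a number 1 percentage points higher from compound 1 to compound 3 (within the scatter). Compound 4 is therefore estimated at 10%, within 0% to 25%.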

Compound 4, a percentage reported as inhibition, at one concentration (the size of the read-out at that concentration, not a potency): 1%
For compound 4 the middle estimate is 9 percentage points above the measured one, within the range that was stated.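

In this assay, putting 2-methyl-1,3-thiazol-4-yl in place of 1,3-oxazol-5-yl gave a number 8 percentage points lower from compound 2 to compound 4 (within the scatter), so on neither core does the change produce a step that stands out from the scatter. Within the data shown here, the two steps also agree with each other, so the change carries over between these two cores without a detectable difference: the same change on two cores in this assay, a number 1 percentage points higher (within the scatter) from compound 1 to compound 3 and a number 8 percentage points lower (within the scatter) from compound 2 to compound 4, 9 percentage points apart, within the scatter of two such steps This shows only that no core dependence can be seen across one pair of steps at a single concentration; it does not show that the two groups are equivalent in general, nor that the agreement would extend to other cores.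

The compounds shown leave open how an amine or a carboxylic acid in place of the five-membered aromatic ring would read in this assay. They also leave open whether a change at the 3-position-bearing phenyl group's other substituent, such as a longer chain, would separate the two cores.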